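The source may report more compounds than this note shows. Statements on the series, on what has been measured and on what is new or still open speak of the compounds shown alone.

Compound 1, `Nc1ccccc1NC(=O)c1ccc(NC(=S)NCc2ccc(Cl)nc2)cc1`, gives in an assay on isolated protein for inhibition of Nicotinamide phosphoribosyltransferase (Homo sapiens), read by fluorescence, with stated times of 5 min and 15 min (on this read-out higher numbers stand for weaker inhibition and lower numbers for stronger inhibition), the limit > 2000 nM.
Compound 2, `Nc1ccccc1NC(=O)c1ccc(NC(=S)NCc2ccccc2F)cc1`, gives in this assay the limit > 2000 nM.

Compound 2 thus stands at a limit of this assay, not at a measured number. The step that the two limits leave unreadable from compound 1 to compound 2 cannot be read from the two values, since both sit at the same limit (the limit of > 2000 nM in this assay, at which 2 of the 2 values shown sit). Compound 3, `Nc1ccccc1NC(=O)c1ccc(NC(=S)NCc2cncc(F)c2)cc1`, differs from compound 2 by 5-fluoropyridin-3-yl in place of 2-fluorophenyl on a saturated chain carbon bound to an amide-type nitrogen. Among the compounds with values here, no measured step bears readably on this change, so no shift beyond the scatter can be expected, and compound 3 is most likely to sit at the limit again. For compound 3 the estimate is 4000 nM, within 2000 nM to 10000 nM, the expected step being a step that the limit leaves unreadable from compound 2 to compound 3.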

Compound 3, half-maximal inhibitory concentration: > 2000 nM
Compound 3: a limit, no number (the forecaster's own chance of this, stated with the estimate: 75%); the middle value does not contradict the limit.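

Within the data shown here, no step among compound 1, compound 2 and compound 3 can be read, since all three give only a limit: the limit of > 2000 nM in this assay, at which 3 of the 3 values shown sit. The compounds shown leave open how strongly each inhibits the protein, and whether exchanging these groups changes that at all.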